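Moving a methyl group on the amide-bound phenyl ring

The source may report more compounds than this note shows. Statements on the series, on what has been measured and on what is new or still open speak of the compounds shown alone.

Measured compounds:
Compound 1, `COc1ccc(NC(=O)c2ccc3cccc(O)c3n2)cc1`: > 30000 nM
Compound 2, `Cc1ccccc1NC(=O)c1ccc2cccc(O)c2n1`: > 30000 nM

In an ADME assay on THP-1 cells (Homo sapiens) for cytotoxicity, read by WST assay, with a stated time of 24 h (on this read-out lower numbers stand for stronger inhibition and higher numbers for weaker inhibition), compound 1 reaches only the limit of the assay, > 30000 nM, which is not a number. Compound 2 likewise gives only a limit in this assay, > 30000 nM. For the measured compounds named here, compound 2 thus stands exactly where every value so far stands: the limit of > 30000 nM in this assay, at which 2 of the 2 values shown sit. Two limits cannot show any difference between the two compounds.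

Compound 3, `Cc1ccc(NC(=O)c2ccc3cccc(O)c3n2)cc1`, has yet to be tested in this assay. It differs from compound 2 by 4-methylphenyl in place of 2-methylphenyl on an amide-type nitrogen. Because both known values sit at the limit (the limit of > 30000 nM in this assay, at which 2 of the 2 values shown sit), there is no basis for expecting a step in either direction beyond the scatter. The step from compound 2 to compound 3 is expected to be a step that the limit leaves unreadable from compound 2 to compound 3, with the outcome most likely to be another limit rather than a number. Compound 3 is therefore estimated at 35000 nM, within a range from 10000 nM to 100000 nM.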

Compound 3, half-maximal inhibitory concentration: > 30000 nM
Compound 3: only a limit was reported; the forecaster's own chance of this, stated with the estimate: 85%; the middle value lies beyond the limit too.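

No step can be read among compound 1, compound 2 and compound 3 in this assay, because each gives only a limit, not a number: the limit of > 30000 nM in this assay, at which 3 of the 3 values shown sit.

The compounds shown leave open whether 4-methylphenyl in place of 2-methylphenyl, or methyl in place of methoxy, changes the true value at all.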